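The source may report more compounds than this note shows. Statements on the series, on what has been measured and on what is new or still open speak of the compounds shown alone.

The account starts with compound 1, `CC(C)c1cccc(C(C)C)c1OC(=O)NS(=O)(=O)N1CCOCC1`, a carbamate whose sulfonyl sulfur carries a morpholin-4-yl group. In an assay on liver for inhibition of sterol O-acyltransferase 1 (Rattus norvegicus), using microsomes (a lower number here means a stronger inhibitor, a higher number a weaker inhibitor), compound 1 gives > 100000 nM, which is a limit of the assay rather than a number. Compound 1 thus sits at the limit of > 100000 nM in this assay, at which 1 of the 2 values shown sits, so its place among the measured values is known only as a boundary. The second measured compound, compound 2, `CCCCCCCCCCCCOS(=O)(=O)NC(=O)Oc1c(C(C)C)cccc1C(C)C`, carries a dodecyloxy group on the same sulfonyl sulfur; in this assay compound 2 gives 13000 nM. Going by the values given here, no step between these two compounds is computed, so only the two values themselves can be set side by side. The unmeasured compound 3, `Cc1cccc(C)c1OS(=O)(=O)NC(=O)Oc1c(C(C)C)cccc1C(C)C`, differs from compound 1 by 2,6-dimethylphenoxy in place of morpholin-4-yl on a sulfonyl sulfur. Since compound 2, which gives 13000 nM, is the nearest relative with an oxygen-linked group in that position, the step from compound 1 to compound 3 is expected to run toward stronger inhibition, although its size is uncertain, and it is estimated as an at least 5.0-fold lower number from compound 1 to compound 3 (0.69 log units; beyond the scatter). For compound 3 the expected value is 20000 nM, within a range from 3000 nM to 100000 nM.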

Compound 3, half-maximal inhibitory concentration: > 50000 nM
Compound 3: no number, only a limit; the forecaster's own chance of this, stated with the estimate: 25%; middle value at least 2.5-fold (0.39 log units) away from the limit.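

Compound 1 and compound 3 are both known in this assay only as limits of the assay, not as numbers, and the step between them cannot be read. The compounds shown leave open how 2,6-dimethylphenoxy in place of morpholin-4-yl on a sulfonyl sulfur changes the value in this assay, in either direction or by any size.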